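Fluoro to Trifluoromethyl on a Series of Inactive Sulfonamides

The source may report more compounds than this note shows. Statements on the series, on what has been measured and on what is new or still open speak of the compounds shown alone.

Three measured compounds share one core and differ only in one group on the sulfonyl-bearing ring. Compound 1 `O=S(=O)(Nc1ccc(-c2nc3ccccc3o2)cc1)c1ccc(O)cc1` carries a hydroxy, and in an assay on isolated protein for inhibition of malate dehydrogenase, mitochondrial (Sus scrofa), with stated times of 45 min and 30 min (a lower number here means a stronger inhibitor, a higher number a weaker inhibitor), compound 1 gives > 63000 nM, which is a limit of the assay, not a number. Compound 2 `CCc1ccc(S(=O)(=O)Nc2ccc(-c3nc4ccccc4o3)cc2)cc1` carries an ethyl, and in this assay compound 2 also gives a limit, > 63000 nM. Compound 3 `O=S(=O)(Nc1ccc(-c2nc3ccccc3o2)cc1)c1ccc(F)cc1` carries a fluoro, and in this assay compound 3 likewise gives a limit, > 63000 nM. All three sit at the limit of > 63000 nM in this assay, at which 3 of the 3 values shown sit, so the steps a step that the two limits leave unreadable from compound 1 to compound 2, a step that the two limits leave unreadable from compound 1 to compound 3 and a step that the two limits leave unreadable from compound 2 to compound 3 bear on the question only as unreadable. Compound 4 `O=S(=O)(Nc1ccc(-c2nc3ccccc3o2)cc1)c1ccc(C(F)(F)F)cc1` differs from compound 3 by trifluoromethyl in place of fluoro on an aromatic carbon. Because every measured value sits at the limit of > 63000 nM in this assay, at which 3 of the 3 values shown sit, compound 4 is expected to remain at the limit, with the step that the limit leaves unreadable from compound 3 to compound 4 estimated as unreadable. The estimate for compound 4 is 90000 nM, ranging from 20000 nM to 400000 nM.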

Compound 4, half-maximal inhibitory concentration: > 63000 nM
Compound 4 ended at the assay's limit; the forecaster's own chance of this, stated with the estimate: 85%; the middle value does not contradict the limit.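

In this assay, among the compounds shown here, compound 4 gives > 63000 nM, a limit and not a number, so no step among compound 1, compound 2, compound 3 and compound 4 can be read. On these data alone, whether any group in this place on the shared core gives a readable value remains open.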